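Mirror-image inversion of the N-methyl core in compound 1

The source may hold more compounds than are shown below. What is called first, only, known or untested is meant among the compounds shown, and "the series" means these compounds.

Compound 1 `CN1C[C@H]2C=C(c3cccnc3)C[C@H](C2)C1` sits second highest of the three numbers in an in vitro assay on SH-SY5Y cells for displacement of a labelled ligand from Neuronal acetylcholine receptor; alpha3/beta4 (Homo sapiens) (a higher number here means a weaker inhibitor, a lower number a stronger inhibitor), where compound 1 gives 534 nM. Its nearest neighbour is compound 3 `CN1CC2C=C(c3ccc(F)nc3)CC(C2)C1`, which in this assay gives 1310 nM; furthest away is compound 2 `C1=C(c2cccnc2)C[C@H]2CNC[C@@H]1C2`, which gives 4 nM. Among the compounds with values here, the one step measured within the set, a 130-fold lower number from compound 1 to compound 2 (2.13 log units; beyond the scatter), concerns hydrogen in place of methyl on the ring amine nitrogen and is large.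

Compound 4 `CN1C[C@@H]2C=C(c3cccnc3)C[C@@H](C2)C1` is not yet measured. It differs from compound 1 only in configuration: the two compounds have the same atoms and bonds and differ only in configuration as drawn: 2 of 2 stereo elements differ (all stereocentres are inverted: mirror images); a stereocentre at a saturated ring carbon is drawn R in compound 1 and S in compound 4; a stereocentre at a saturated ring carbon is drawn S in compound 1 and R in compound 4. Within the data shown here, none of the measured steps bears on this change; the step from compound 1 to compound 2 alters a substituent, not the drawn configuration, and compound 3 is drawn without defined stereocentres, so it gives no comparison either. There is therefore no measured basis for a direction, and the expectation rests only on compound 1 itself. The working estimate for compound 4 is a step of a 1.1-fold lower number from compound 1 to compound 4 (0.03 log units; within the scatter), that is no change beyond the scatter, but with a wide range to allow for either enantiomer being the better one. Compound 4 is accordingly expected at 500 nM, within 100 nM to 2500 nM.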

Compound 4, inhibition constant: 1800 nM
Beside the measured number, compound 4's estimate is 3.6-fold (0.56 log units) below it; measured number inside the range.
By their numbers in this assay, from the lowest: compound 2; then compound 1; then compounds 3 and 4 (each within the scatter of the next).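

Configuration at the two stereocentres of the shared core counts in this assay: inverting both gives a 3.4-fold higher number from compound 1 to compound 4 (0.53 log units; beyond the scatter), a modest step but one beyond the scatter. Within the data shown here, the earlier compounds could not show this, as the only step then available changed a substituent, and the step here can be assigned to configuration alone because nothing else in the structures has changed: the fact that compounds 1 and 4 differ only in the configuration as drawn. The mirror-image step is nevertheless much smaller than a 130-fold lower number from compound 1 to compound 2 (2.13 log units; beyond the scatter), so among the changes on compound 1 shown here, replacing methyl with hydrogen on the ring amine nitrogen moves the number far more than inverting the core, and compound 1 is the better of the two enantiomers by this measure.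

The compounds shown leave open whether the same preference for one configuration, and a step of similar size, holds on the core of compound 2, which carries hydrogen on the ring amine nitrogen, or for the fluorine-bearing compound 3, which is drawn without defined stereocentres. They also leave open how a larger group on that nitrogen, such as ethyl or a longer alkyl chain, would behave in either configuration.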